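The source may report more compounds than this note shows. Statements on the series, on what has been measured and on what is new or still open speak of the compounds shown alone.

Measured so far, in a functional assay on ACHN cells (Homo sapiens) for inhibition, read by sulforhodamine B assay; a higher number here means a weaker inhibitor of growth, a lower number a stronger inhibitor of growth:
- compound 1 `CC(=O)Nc1ccc(CN2CCC=C(CCC(=O)NO)C2=O)cc1`: "not determined" (no result reported)
- compound 2 `Cc1ccc(CN2CCC=C(CCC(=O)NO)C2=O)cc1`: 5000 nM
- compound 3 `COc1ccc(CN2CCC=C(CCC(=O)NO)C2=O)cc1`: 1670 nM

In this assay, compound 3 has the lower of the two numbers available, at 1670 nM. Compound 2 stands at 5000 nM, and compound 1 has no number to compare.

The next structure is compound 4 `O=C(CCC1=CCCN(Cc2ccc(NC(=O)c3ccccc3)cc2)C1=O)NO`. The change is benzamido in place of methoxy on an aromatic carbon, para to a large group.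

Within the data shown here, only one measured step bears on this position: a 3.0-fold lower number from compound 2 to compound 3 (0.48 log units; beyond the scatter), a modest change beyond the scatter. It involves only a small group, so it is a weak guide to the much larger benzamido. Compound 1 also carries an amide at this place, but with no number it cannot bridge the gap.

Among the measured compounds shown here, with a 3.0-fold lower number from compound 2 to compound 3 (0.48 log units; beyond the scatter) as the only guide to size, a modest move toward a lower number is expected, though the data do not secure the direction. The estimated step is a 2.4-fold lower number from compound 3 to compound 4 (0.38 log units; beyond the scatter). For compound 4 the expected value is 700 nM, with an estimated range of 180 nM to 2800 nM.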

Compound 4, concentration for 50% growth inhibition: > 10000 nM
Compound 4: no number, only a limit; the forecaster's own chance of this, stated with the estimate: 5%; at least 14-fold (1.15 log units) between middle value and limit.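

In this assay compound 4 carries a limit of the assay and not a number: the limit of > 10000 nM in this assay, at which 1 of the 4 values shown sits.

Among these compounds, this position does not respond to benzamido as it did to the small groups: the only earlier step went to a lower number (a 3.0-fold lower number from compound 2 to compound 3 (0.48 log units; beyond the scatter)), whereas the new step goes the other way and is larger (an at least 5.9-fold higher number from compound 3 to compound 4 (0.77 log units; beyond the scatter)). The comparison with the methyl compound is less firm, since its floor lies within the scatter (an at least 2.0-fold higher number from compound 2 to compound 4 (0.30 log units; that floor lies within the scatter)), so the clear loss here is measured against methoxy only.

The compounds shown do not separate the contribution of the amide link from that of the added six-membered aromatic ring, as compound 1 holds an amide at this place but has no result to compare. Also open, on these data alone, is how the series behaves with an amine or a carboxylic acid on this aromatic carbon, and whether the lower number of compound 3 marks a narrow preference for methoxy or extends to other small groups such as chloro or ethoxy.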